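Chlorinated purine series: cytotoxicity on melanoma cells

The source may hold more compounds than are shown below. What is called first, only, known or untested is meant among the compounds shown, and "the series" means these compounds.

Three compounds built on a shared core carrying a chloromethylbenzyl arm have been measured in a functional assay on SK-MEL-5 cells (Homo sapiens) for cytotoxicity, read by sulforhodamine B assay, with a stated time of 48 h; a lower number here means that less compound is tolerated, a higher number that more compound is tolerated. Compound 1 `ClCc1ccccc1Cn1cnc2c(Cl)ncnc21` gives 5880 nM. Compound 2 `ClCc1ccccc1Cn1cnc2ncnc(Cl)c21` gives 15800 nM, the second highest of the three numbers; its nearest neighbour is compound 1, with a lower number beyond the scatter, and its furthest is compound 3 `Nc1nc(Cl)c2ncn(Cc3cccc(CCl)c3)c2n1`, which in this assay gives 51300 nM, beyond the scatter in the other direction. Among the measured compounds shown here, no pair among the three differs in one place only, so no single-change step is available from the measured set.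

Compound 4 `ClCc1ccccc1Cn1cnc2nc(Cl)nc(Cl)c21` has not yet been measured. It differs from compound 2 by chloro in place of hydrogen on an aromatic carbon, placed between two ring nitrogen atoms and meta to a chloro group. The measured set offers no comparable change, so the size of the step can only be guessed. A chloro in place of hydrogen on the core is expected to shift tolerance little, if at all, with the estimated step from compound 2 to compound 4 being a 1.4-fold lower number from compound 2 to compound 4 (0.16 log units; within the scatter), at most modestly downward. Compound 4 is thus expected to give about 11000 nM in this assay, within a range from 3500 nM to 35000 nM.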

Compound 4, concentration lethal to 50% of the cells: 5490 nM
Beside the measured number, compound 4's estimate is 2.0-fold (0.30 log units) above it; low and high end bracket the measured number.
By their numbers in this assay, from the lowest: compounds 4 and 1 (each within the scatter of the next); then compound 2; then compound 3.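

Chloro in place of hydrogen on an aromatic carbon, placed between two ring nitrogen atoms, gives the first single-change step of the series in this assay with a 2.9-fold lower number from compound 2 to compound 4 (0.46 log units; beyond the scatter) as its size. The number at this position therefore responds to the substituent: the step is modest but lies beyond the scatter, and it runs towards less compound being tolerated. No measurement shown accounts for this shift.

Going by these compounds, whether a methyl group, a methoxy group or a longer chain at the same position would move the number in the same direction remains open, as a single substituent defines no trend. Also open, on these data alone, is whether the same chloro change on the core of compound 1 would give a step of similar size.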